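The compounds below may be only part of what the source reports. "The series", "measured", "known", "first", "only" and "open" are said of these compounds alone.

Measured compounds:
Compound 1, `COc1cc(-c2cc(/C=C/C(=O)c3ccc(N)cc3)[nH]n2)cc(OC)c1OC`, gives 3280 nM in a functional assay on LOX IMVI cells (Homo sapiens) for inhibition, read by sulforhodamine B assay, with a stated time of 48 h; a lower number here means a stronger inhibitor of growth, a higher number a weaker inhibitor of growth.
Compound 2, `COc1ccc(C(=O)/C=C/c2cc(-c3cc(OC)c(OC)c(OC)c3)n[nH]2)cc1OC`, gives 2760 nM in this assay.

Compound 2 has the lowest of the two numbers, yet the gap to compound 1 is small: a 1.2-fold lower number from compound 1 to compound 2 (0.07 log units; within the scatter), a change of the aryl group on the carbonyl carbon that made no difference beyond the scatter. The next compound, compound 3, `COc1ccc(C(=O)/C=C/c2cc(-c3cc(OC)c(OC)c(OC)c3)n[nH]2)cc1`, again alters the same part of the molecule: hydrogen in place of methoxy on an aromatic carbon. Going by the values given here, no measured step removes a methoxy group from this ring, so the only guide is that the one change already made here, from compound 1 to compound 2, left this assay essentially unmoved. Compound 3 is therefore expected to stay close to compound 2, with a step of about a 1.1-fold higher number from compound 2 to compound 3 (0.04 log units; within the scatter), no larger than the scatter. The estimate for compound 3 is 3000 nM, with a likely range from 1200 nM to 7500 nM.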

Compound 3, concentration for total growth inhibition: 3020 nM
Estimate against measurement, compound 3: 1.0-fold (0.00 log units) below; the measured number falls inside the stated range.
By their numbers in this assay, from the lowest: compounds 2, 3 and 1 (each within the scatter of the next).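

Going from 3,4-dimethoxyphenyl to 4-methoxyphenyl on the carbonyl carbon keeps the number within the scatter in this assay (a 1.1-fold higher number from compound 2 to compound 3 (0.04 log units; within the scatter)). Methoxy in place of amino on that ring is likewise within the scatter (a 1.1-fold lower number from compound 1 to compound 3 (0.04 log units; within the scatter)), so the three aryl groups now compared at this carbonyl carbon all lie within the scatter of one another, where the earlier pair offered a single comparison. Nothing available explains why these changes leave the number in the same range.

As far as these compounds go, it remains open whether a plain phenyl group, or a ring carrying a carboxylic acid or trifluoromethyl group, would stay within this range. The compounds shown also leave the rest of the shared core unchanged, so what a different group elsewhere on it would do is unknown.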